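This account rests on a few compounds, and the source may have more. Where it says the series, first, only, none or still open, it means among the compounds named here.

For the measured compounds named here, compound 2 `Cc1cc(C)n(CCOC2CC(=O)Nc3c2c(C)nn3-c2ncnc3nc[nH]c23)n1` gives the highest of the two numbers so far in a functional assay on HEK293 cells for agonist activity at G-protein coupled receptor 39 (Homo sapiens), read by scintillation proximity assay and inositol phosphate accumulation, with a stated time of 75 min (a higher number here means that more compound is needed for the effect, a lower number that less compound is needed), at 2000 nM; compound 1 `Cc1nn(-c2ncnc3nc[nH]c23)c2c1C(OCCc1ccccc1)CC(=O)N2` gives 40 nM, and the step of a 50-fold higher number from compound 1 to compound 2 (1.70 log units; beyond the scatter) separates them. Compound 3 `Cc1nn(-c2ncnc3nc[nH]c23)c2c1C(OCCn1cccn1)CC(=O)N2` differs from compound 2 by 1H-pyrazol-1-yl in place of 3,5-dimethyl-1H-pyrazol-1-yl on a saturated chain carbon, two bonds along the chain from an oxygen on a saturated carbon. Going by the values given here, no measured step removes methyl groups from this ring; the only step at this place, a 50-fold higher number from compound 1 to compound 2 (1.70 log units; beyond the scatter), shows that the group here can move the number a great deal, but it alters a different part of the group. The expected step is therefore modest, a 2.0-fold lower number from compound 2 to compound 3 (0.30 log units; within the scatter), with wide uncertainty. Compound 3 is expected to give 1000 nM in this assay, within 250 nM to 4000 nM.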

Compound 3, half-maximal effective concentration: 2270 nM
Compound 3: the middle estimate sits 2.3-fold (0.36 log units) below what was measured; measured number inside the range.
By their numbers in this assay, from the lowest: compound 1; then compounds 2 and 3 (each within the scatter of the next).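

In this assay, the two methyl groups of 3,5-dimethyl-1H-pyrazol-1-yl have no readable effect at this position: 1H-pyrazol-1-yl in its place gives a 1.1-fold higher number from compound 2 to compound 3 (0.05 log units; within the scatter). The large gap to phenyl persists without them, with a 57-fold higher number from compound 1 to compound 3 (1.75 log units; beyond the scatter), so across these compounds it goes with 1H-pyrazol-1-yl or its dimethyl form replacing phenyl, not with the methyl groups. Nothing available gives a reason for this gap. Still open, on these data alone, is whether a pyridyl or fluorophenyl group on this chain would stay close to compound 1, and whether a longer chain would change the picture.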